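A Benzamide Variant of an Amide Series Without Measured Potency

The source may report more compounds than this note shows. Statements on the series, on what has been measured and on what is new or still open speak of the compounds shown alone.

The shared core carries an amide whose acyl group is varied. Compound 1 `O=C(Nc1ccc(Cl)c(-c2nnc3c(Cl)cccn23)c1)c1ccc(Cl)cc1Cl` bears a 2,4-dichlorophenyl on the carbonyl carbon. In a functional assay on U-251 cells (Homo sapiens) for antiproliferative activity, read by MTT assay, with a stated time of 72 h (a higher number here means a weaker inhibitor, a lower number a stronger inhibitor), compound 1 gives only a limit of the assay, > 100000 nM, and not a number. Compound 2 `O=C(Nc1ccc(Cl)c(-c2nnc3c(Cl)cccn23)c1)c1cccnc1Cl` carries a 2-chloropyridin-3-yl on that carbonyl carbon. In this assay compound 2 likewise gives a limit of the assay, > 100000 nM. For the measured compounds named here, the step that the two limits leave unreadable from compound 1 to compound 2 cannot be read because both of its ends are limits, and compound 2 therefore stands at the assay limit together with the one other value shown (the limit of > 100000 nM in this assay, at which 2 of the 2 values shown sit).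

Compound 3 `O=C(Nc1ccc(Cl)c(-c2nnc3c(Cl)cccn23)c1)c1ccccc1` arises from compound 2 by the change (phenyl in place of 2-chloropyridin-3-yl on a carbonyl carbon). Going by the values given here, the only measured step that bears on it is a step that the two limits leave unreadable from compound 1 to compound 2, whose size is not readable. With both measured values sitting at the limit, no direction beyond the scatter can be expected. The step expected is a number no higher from compound 2 to compound 3 (the limit leaves the size open). In this assay compound 3 is expected to give about 100000 nM, between 20000 nM and 300000 nM, most probably again as a limit rather than a number.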

Compound 3, half-maximal inhibitory concentration: 73500 nM
For compound 3 the middle estimate is 1.4-fold (0.13 log units) above the measured one; the range from low to high includes it.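

For the compounds shown here, with phenyl on the carbonyl carbon, compound 3 is the only one of the three compounds that gives a number and not a limit of the assay in this assay, at 73500 nM. Taking phenyl in place of the 2-chloropyridin-3-yl gives an at least 1.3-fold lower number from compound 2 to compound 3 (0.13 log units; that floor lies within the scatter), and taking it in place of the 2,4-dichlorophenyl gives an at least 1.3-fold lower number from compound 1 to compound 3 (0.13 log units; that floor lies within the scatter), so each step is known only as a floor and neither establishes a change beyond the scatter. The step between compound 1 and compound 2 still cannot be read, and the true size of the two new steps stays open above their floors: the limit of > 100000 nM in this assay, at which 2 of the 3 values shown sit.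

Nothing shown tells how an acetyl group, a longer alkyl chain, or a phenyl carrying an amine or a carboxylic acid would read on this carbonyl carbon in this assay. From the compounds shown here alone, all three compounds also share the same chlorines on the core, so what replacing those with hydrogen or with methoxy would do to the number remains open.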